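The source may hold more compounds than are shown below. What is called first, only, known or untested is meant among the compounds shown, and "the series" means these compounds.

Measured so far in a functional assay on Ishikawa cells (Homo sapiens) for antiproliferative activity, read by CCK-8 assay, with a stated time of 48 h; a higher number here means a weaker inhibitor, a lower number a stronger inhibitor:
compound 1 `C=C(C)C(=O)NCCOc1ccc(Oc2c(-c3ccc(F)cc3)sc3cc(O)ccc23)cc1`: > 25000 nM (a limit, not a number)
compound 2 `C/C=C/C(=O)N1CC(Oc2ccc(Oc3c(-c4ccc(F)cc4)sc4cc(O)ccc34)cc2)C1`: 9400 nM
compound 3 `CN(C)C(=O)/C=C/CNCCOc1ccc(Oc2c(-c3ccc(F)cc3)sc3cc(O)ccc23)cc1`: 11900 nM

Among the measured compounds shown here, compound 2 (9400 nM) has only one other true number to stand against, and the gap is small (a 1.3-fold higher number from compound 2 to compound 3 (0.10 log units; within the scatter)). Compound 1 gives only a limit (> 25000 nM).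

Compound 4 `O=C(/C=C/CN1CC(Oc2ccc(Oc3c(-c4ccc(F)cc4)sc4cc(O)ccc34)cc2)C1)N1CCC1` is still unmeasured. It differs from compound 2 by 3-((azetidin-1-yl)carbonyl)prop-2-en-1-yl in place of (prop-1-en-1-yl)carbonyl on an amine nitrogen in a ring.

The closest measured change also acts on an amine nitrogen, with 3-(dimethylcarbamoyl)prop-2-en-1-yl entering (an at least 2.1-fold lower number from compound 1 to compound 3 (0.32 log units; beyond the scatter)). The other step from the limit is of similar standing (an at least 2.6-fold lower number from compound 1 to compound 2 (0.42 log units; beyond the scatter)). From the compounds shown here alone, both start from a limit, so their true sizes remain open. The step that brings in the same dimethylcarbamoyl group on a different link stays within the scatter (a 1.3-fold higher number from compound 2 to compound 3 (0.10 log units; within the scatter)), which argues against a large change.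

In this assay a small move towards a lower number is therefore expected, probably not clearly beyond the scatter. The expected step is modest (a 1.6-fold lower number from compound 2 to compound 4 (0.19 log units; within the scatter)). The estimate for compound 4 is 6000 nM, with an expected range from 1800 nM to 20000 nM.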

Compound 4, half-maximal inhibitory concentration: 5450 nM
For compound 4 the middle estimate is 1.1-fold (0.04 log units) above the measured one; low and high end bracket the measured number.
By their numbers in this assay, from the lowest: compounds 4, 2 and 3 (each within the scatter of the next, the first and the last beyond it). At a limit, above all of these: compound 1.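

In this assay, placing 3-((azetidin-1-yl)carbonyl)prop-2-en-1-yl on the amine nitrogen in the four-membered ring, in place of (prop-1-en-1-yl)carbonyl, gives a 1.7-fold lower number from compound 2 to compound 4 (0.24 log units; within the scatter). Among the compounds shown here, this is the first readable step at this ring nitrogen, and it stays within the scatter, so the larger entering group, which carries its own four-membered ring, is tolerated here without a clear change in either direction. The earlier steps from compound 1 cannot be read as sizes, as its value is a limit and not a number: the limit of > 25000 nM in this assay, at which 1 of the 4 values shown sits.

From the compounds shown here alone, it remains open whether a piperidine amide or a morpholine amide in place of the azetidine amide would give a step beyond the scatter, and the same holds for a carboxylic acid at that end of the chain. Also open, going by these compounds, is whether a saturated chain in place of the prop-2-en-1-yl part, or a longer chain, would leave the number within the scatter of compound 2.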